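A few compounds are considered here, and "the series" means these few. Any claim that something is new, unique, unknown or untested is made for them only; others in the source may bear on it.

Compound 1 `CCOC(=O)c1sc(-c2cccc(NC(=O)c3ccc(C(F)(F)F)cc3)c2)nc1Nc1ccc(N2CCN(C)CC2)cc1` gives 33% in a functional assay on Raji cells (Homo sapiens) for antiproliferative activity, read by CCK-8 assay, with a stated time of 72 h, tested at 40 uM; on this read-out lower numbers stand for less inhibition and higher numbers for more inhibition at the one concentration tested (going by the name of the read-out).
Compound 2 `CN1CCN(c2ccc(Nc3nc(-c4cccc(NC(=O)c5cccc(F)c5)c4)sc3C(=O)O)cc2)CC1` gives 76.3% in this assay.
Compound 3 `CN1CCN(c2ccc(Nc3nc(-c4cccc(NC(=O)c5ccc(C(F)(F)F)cc5)c4)sc3C(N)=O)cc2)CC1` gives 91.9% in this assay.

Compound 3 stands highest of the three numbers in this assay; compound 2 is nearest, a number beyond the scatter below it, and compound 1 is furthest, well beyond the scatter below it. Among the compounds with values here, the only single-place step measured, a number 58.9 percentage points higher from compound 1 to compound 3 (beyond the scatter), concerns the group on the carbonyl carbon, not the ring where compound 4 `CN1CCN(c2ccc(Nc3nc(-c4cccc(NC(=O)c5ccc(Cl)cc5)c4)sc3C(N)=O)cc2)CC1` differs from compound 3: chloro in place of trifluoromethyl on an aromatic carbon. Within the data shown here, no measured step touches that position, so nothing measured bears directly on this change. Compound 2 differs from compound 3 in more than one place, so its value shows only that a different pattern of changes gives a lower number. Since the shared core with the amide at the carbonyl carbon is kept, no step beyond the scatter is expected, with a small drift downward left open because compound 3 already lies close to the top of the scale at 91.9%. Compound 4 is therefore estimated at 85%, between 65% and 97%, an expected step of a number 6.9 percentage points lower from compound 3 to compound 4 (within the scatter).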

Compound 4, a percentage reported as inhibition, at one concentration (the size of the read-out at that concentration, not a potency): 92.6%
Compound 4: the middle estimate sits 7.6 percentage points below what was measured; the range from low to high includes it.
By their numbers in this assay, from the lowest: compound 1; then compound 2; then compounds 3 and 4 (each within the scatter of the next).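

In this assay, putting chloro in place of trifluoromethyl on this aromatic carbon, para to a large group, gives a number 0.7 percentage points higher from compound 3 to compound 4 (within the scatter). Within the data shown here, this is the first direct reading at this position: with the amino group on the carbonyl carbon kept, one chlorine atom can stand where the four heavy atoms of trifluoromethyl stood with no change that rises above the scatter. Nothing on hand explains why the two groups read alike.

Both numbers come from one concentration and lie near the top of the scale, so they do not show how the two compounds compare in potency. Also open, from the compounds shown here alone, is whether a methoxy group or an amine at this place would read the same, and whether chloro would match trifluoromethyl with ethoxy on the carbonyl carbon.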